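The source may hold more compounds than are shown below. What is called first, only, known or untested is meant among the compounds shown, and "the series" means these compounds.

Working notes on the series.

Compound 1 `CCCCCn1c(Cc2cc(OC)c(OC)c(OC)c2)nc2c(N)ncnc21` is the reference point: in a functional assay on MCF7 cells (Homo sapiens) for antiproliferative activity (a higher number here means a weaker inhibitor, a lower number a stronger inhibitor), compound 1 gives 61700 nM. Compound 2 `COc1cc(Cc2nc3c(N)ncnc3n2CCCC(C)C)cc(OC)c1OC` carries the change methyl in place of hydrogen on a saturated chain carbon bound to two saturated chain carbons and in this assay compound 2 gives 69200 nM; the step is a 1.1-fold higher number from compound 1 to compound 2 (0.05 log units; within the scatter), so the two values are not separable here.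

Compound 3 `CCCn1c(Cc2cc(OC)c(OC)c(OC)c2)nc2c(N)nc(F)nc21` belongs to a different core; the difference between the two cores is not broken down here. In this assay compound 3 gives 25100 nM, the lowest number of the three measured, and its distance from compound 1 and from compound 2 lies beyond the scatter.

Compound 4 `CCCCn1c(Cc2cc(OC)c(OC)c(OC)c2)nc2c(N)nc(F)nc21` is compound 3 with methyl in place of hydrogen on a saturated chain carbon, three bonds along the chain from an aromatic nitrogen. This is the same kind of change as that from compound 1 to compound 2, but not the same: there the methyl sat on a saturated chain carbon bound to two saturated chain carbons, here it sits on a saturated chain carbon, three bonds along the chain from an aromatic nitrogen. Given that the earlier step was a 1.1-fold higher number from compound 1 to compound 2 (0.05 log units; within the scatter), a step of a 1.1-fold lower number from compound 3 to compound 4 (0.04 log units; within the scatter) is expected. Compound 4 is estimated at 23000 nM, between 9000 nM and 55000 nM.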

Compound 4, half-maximal inhibitory concentration: 24000 nM
Estimate against measurement, compound 4: 1.0-fold (0.02 log units) below; low and high end bracket the measured number.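

On the core of compound 3, the added methyl gives a 1.0-fold lower number from compound 3 to compound 4 (0.02 log units; within the scatter) in this assay, so the two values are not separable. Set beside the earlier step, the same kind of change reads alike on both cores: the same change on two cores in this assay, a 1.1-fold higher number (0.05 log units; within the scatter) from compound 1 to compound 2 and a 1.0-fold lower number (0.02 log units; within the scatter) from compound 3 to compound 4, 1.2-fold (0.07 log units) apart, within the scatter of two such steps. This shows only that the methyl leaves no readable mark on either core in these two pairs; it does not show that a step of real size would carry over, that the cores respond alike to other changes, or that place on the chain is irrelevant, as the methyl sits at a different place on the chain in each pair.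

The compounds shown leave open whether an amine, a carboxylic acid or a longer chain in place of these alkyl chains would move the number beyond the scatter on either core. Going by these compounds, they also pair each core with different chains, so what the core alone contributes stays open.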